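A few compounds are considered here, and "the series" means these few. Any claim that something is new, unique, unknown or untested is made for them only; others in the source may bear on it.

The measured compounds in a functional assay on SH-SY5Y cells (Homo sapiens) for cytotoxicity, read by MTT assay, with a stated time of 48 h; a lower number here means a stronger inhibitor, a higher number a weaker inhibitor:
- compound 1 `FC(F)=C(F)CCSc1nnc(S)s1`: > 120000 nM
- compound 2 `FC(F)(Cl)C(F)(Cl)CCSc1nc2ccc(Cl)cc2s1`: > 120000 nM
- compound 3 `O=S(=O)(CCC(F)=C(F)F)c1nc2ccccc2[nH]1`: > 120000 nM

Each of these values is a limit of the assay, not a number. Compound 2 therefore stands nowhere distinct: its reading is > 120000 nM, a limit. Compound 1 likewise shows > 120000 nM, a limit. Compound 3 shows > 120000 nM, a limit. All three readings rest at the limit of > 120000 nM in this assay, at which 3 of the 3 values shown sit, so no ordering among them can be drawn.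

Compound 4 `FC(F)(Cl)C(F)(Cl)CCSc1nc2ccccc2s1` differs from compound 2 by hydrogen in place of chloro on an aromatic carbon. For the measured compounds named here, with no measured pair showing such a change, the expected step of a number no higher from compound 2 to compound 4 (the limit leaves the size open) in this assay is none beyond the scatter, and compound 4 is expected to remain at the limit, estimated as 120000 nM within 60000 nM to 300000 nM.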

Compound 4, half-maximal inhibitory concentration: > 120000 nM
Compound 4 ended at the assay's limit (the forecaster's own chance of this, stated with the estimate: 85%); the middle value sits exactly at the limit.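

No step can be read from compound 2 to compound 4, because both readings are limits of the assay and not numbers: the limit of > 120000 nM in this assay, at which 4 of the 4 values shown sit. The compounds shown leave open how strongly any of them acts on these cells, and whether hydrogen in place of chloro changes that.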